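A few compounds are considered here, and "the series" means these few. Any claim that something is new, unique, unknown or untested is made for them only; others in the source may bear on it.

Compound 1 `Nc1nc(N)c2c(-c3ccsc3)cn([C@@H]3O[C@H](CO)[C@@H](O)[C@H]3O)c2n1`: in an ADME assay on BJ cells (Homo sapiens), read by MTT assay, with a stated time of 72 h (on this read-out higher numbers stand for weaker inhibition and lower numbers for stronger inhibition), compound 1 gives > 100000 nM, which is a limit of the assay and not a number.
Compound 2 `Cc1nc(N)c2c(-c3cc4ccccc4o3)cn([C@@H]3O[C@H](CO)[C@@H](O)[C@H]3O)c2n1`: in this assay compound 2 gives > 100000 nM, again a limit.
Compound 3 `Nc1nc(N)c2c(-c3ccoc3)cn([C@@H]3O[C@H](CO)[C@@H](O)[C@H]3O)c2n1`: in this assay compound 3 gives > 100000 nM, also a limit.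

Compound 3 therefore stands at a limit only, and all three values shown sit at the same limit (the limit of > 100000 nM in this assay, at which 3 of the 3 values shown sit). For the measured compounds named here, the one measured step that touches compound 3, a step that the two limits leave unreadable from compound 1 to compound 3, is unreadable for the same reason, so no size can be taken from it.

Compound 4 `Nc1nc(N)c2c(-c3cc4ccccc4o3)cn([C@@H]3O[C@H](CO)[C@@H](O)[C@H]3O)c2n1` differs from compound 3 in one place: 1-benzofuran-2-yl in place of furan-3-yl on an aromatic carbon. Compound 2 carries the same 1-benzofuran-2-yl group and reaches only a limit as well. Going by the values given here, no measured step gives a readable size, so nothing beyond the scatter can be expected in either direction. Compound 4 is expected to sit at the limit too, with an estimate of 150000 nM in this assay, between 50000 nM and 500000 nM. The step that the limit leaves unreadable from compound 3 to compound 4 is accordingly expected to be within the scatter.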

Compound 4, half-maximal inhibitory concentration: > 100000 nM
Compound 4: only a limit was reported (the forecaster's own chance of this, stated with the estimate: 85%); the middle value lies beyond the limit too.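

Compound 4 gives > 100000 nM in this assay, which is a limit, so the steps from compounds 1, 2 and 3 to compound 4 cannot be read: the limit of > 100000 nM in this assay, at which 4 of the 4 values shown sit.

The compounds shown leave open whether any group on the shared core gives a readable value in this assay.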